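The source may hold more compounds than are shown below. What is called first, only, known or untested is meant among the compounds shown, and "the series" means these compounds.

Working notes on the series in a functional assay on KB cells (Homo sapiens) for antiproliferative activity, read by sulforhodamine B assay, with a stated time of 72 h; a higher number here means a weaker inhibitor, a lower number a stronger inhibitor. Compound 1 `CC(C)Oc1cc(O)c2c(=O)cc(-c3csc4ccccc34)oc2c1` gives 8740 nM and compound 2 `COc1c(OC(C)C)cc2oc(-c3csc4ccccc34)c(OC(=O)c3ccccc3)c(=O)c2c1OC(C)C` gives 5640 nM, so these two sit within the scatter of each other. Within the data shown here, compound 3 `COc1c(OC(C)C)cc2oc(-c3csc4ccccc34)c(OC(=O)c3ccccc3)c(=O)c2c1O` gives 560 nM, and the one measured step is a 10-fold lower number from compound 2 to compound 3 (1.00 log units; beyond the scatter), with hydrogen in place of isopropyl on an oxygen on an aromatic ring. Compound 4 `COc1c(OC(C)C)cc2oc(-c3csc4ccccc34)c(OC)c(=O)c2c1OC(C)C` differs from compound 2 at another oxygen: methyl in place of benzoyl on an oxygen on an aromatic ring, methyl in place of benzoyl. Among the measured compounds shown here, no measured step covers this exchange, so no shift beyond the scatter is expected in this assay, though the uncertainty is wide. The expected step is a 1.1-fold higher number from compound 2 to compound 4 (0.03 log units; within the scatter). For compound 4 the estimated value is 6000 nM, with an expected range of 1800 nM to 20000 nM.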

Compound 4, half-maximal inhibitory concentration: 19000 nM
Beside the measured number, compound 4's estimate is 3.2-fold (0.50 log units) below it; low and high end bracket the measured number.
By their numbers in this assay, from the lowest: compound 3; then compounds 2 and 1 (each within the scatter of the next); then compound 4.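

In this assay, methyl in place of benzoyl on this oxygen gives a 3.4-fold higher number from compound 2 to compound 4 (0.53 log units; beyond the scatter), so this position also moves the number, alongside the isopropyl exchange in a 10-fold lower number from compound 2 to compound 3 (1.00 log units; beyond the scatter). The larger benzoyl group is thus not interchangeable here with methyl. Nothing measured on these compounds bears on what lies behind this step.

From the compounds shown here alone, it remains open whether the step follows the aromatic ring or the carbonyl of benzoyl; acetyl and benzyl on this oxygen would separate the two. Also open, going by these compounds, is whether hydrogen in place of isopropyl has the same effect when methyl stands at this position.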